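The source may report more compounds than this note shows. Statements on the series, on what has been measured and on what is new or still open speak of the compounds shown alone.

Values so far in a physicochemical assay for solubility, in phosphate buffer, with a stated time of 24 h, at pH 7.4, tested at 100 uM (on this read-out higher numbers stand for higher solubility and lower numbers for lower solubility), are:

- compound 1 `O=C(NCc1ccc(S(=O)(=O)c2ccccc2)cc1)N1Cc2ccncc2C1` gives 115000 nM
- compound 2 `CC(=O)N1CCC(S(=O)(=O)c2ccc(CNC(=O)N3Cc4ccncc4C3)cc2)CC1` gives 187000 nM
- compound 3 `CCC(=O)N1CCC(S(=O)(=O)c2ccc(CNC(=O)N3Cc4ccncc4C3)cc2)CC1` gives 216000 nM

Compound 3 lies within the scatter of both other compounds, so the three cannot be ranked. Compound 4 `O=C(NCc1ccc(S(=O)(=O)C2CCN(C3COC3)CC2)cc1)N1Cc2ccncc2C1` carries oxetan-3-yl in place of propanoyl on an amine nitrogen in a ring. Among the measured compounds shown here, no measured step makes this exact exchange. The closest are a 1.2-fold higher number from compound 2 to compound 3 (0.06 log units; within the scatter) for an added methyl, plus a 1.6-fold higher number from compound 1 to compound 2 (0.21 log units; within the scatter) and a 1.9-fold higher number from compound 1 to compound 3 (0.27 log units; within the scatter) for replacing phenyl on a sulfonyl sulfur. All three stay within the scatter, so the expected step is small, a 1.1-fold lower number from compound 3 to compound 4 (0.03 log units; within the scatter) in this assay and with no clear direction. Compound 4 is estimated at 200000 nM (expected range 100000 nM to 400000 nM).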

Compound 4, solubility: 121000 nM
Estimate against measurement, compound 4: 1.7-fold (0.22 log units) above; measured number inside the range.
By their numbers in this assay, from the lowest: compounds 1, 4, 2 and 3 (each within the scatter of the next).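

In this assay, the piperidine nitrogen tolerates a change from acyl groups to a ring: oxetan-3-yl in place of propanoyl gives a 1.8-fold lower number from compound 3 to compound 4 (0.25 log units; within the scatter) and oxetan-3-yl in place of acetyl gives a 1.5-fold lower number from compound 2 to compound 4 (0.19 log units; within the scatter). Against the phenyl of compound 1, the whole 1-(oxetan-3-yl)piperidin-4-yl group gives a 1.1-fold higher number from compound 1 to compound 4 (0.02 log units; within the scatter). Nothing available explains these steps. As far as these compounds go, whether a carboxylic acid or a longer chain on that nitrogen would move the number beyond the scatter remains open.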